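The source may report more compounds than this note shows. Statements on the series, on what has been measured and on what is new or still open speak of the compounds shown alone.

Measured compounds:
compound 1 `Nc1nc(O)c2c(n1)n(C1OC(CO)[C@@H](O)[C@H]1O)c(=O)n2CC(O)CO` — 136%
compound 2 `C=CCn1c(=O)n(CCCCCCCC)c2nc(N)nc(O)c21` — 130%
compound 3 `C=CCn1c(=O)n([C@@H]2O[C@H](CO)[C@H]3OC(CCC)(CCC)O[C@H]32)c2nc(N)nc(O)c21` — 123%

All three were read in a functional assay on the whole organism (B cells) with Mus musculus as the target; a higher number here means a larger maximal response, a lower number a smaller maximal response. Compound 1 holds the highest of the three numbers, but compound 2 lies within the scatter of it, so no order between these two is claimed; compound 3 lies beyond the scatter, on the lower side. Going by the values given here, no pair of measured compounds differs in one place only, so no single-point step is available as a guide, and the three values together cover a narrow band.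

Compound 4 `N#Cc1cccc(Cn2c(=O)n(C3OC(CO)[C@@H](O)[C@H]3O)c3nc(N)nc(O)c32)c1` has not yet been measured. Relative to compound 1 the change is 3-cyanophenyl in place of 1,2-dihydroxyethyl on a saturated chain carbon bound to an aromatic nitrogen. Among the compounds with values here, with no comparable step among the measured compounds, the expectation rests on the narrow band of the three values: a step from compound 1 to compound 4 no larger than the scatter, if anything slightly downward, is expected, written as a number 11 percentage points lower from compound 1 to compound 4 (beyond the scatter). Compound 4 is thus estimated at 125%, with a range from 100% to 150%.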

Compound 4, largest response reached (reported as maximal response), in percent of the reference or control that the assay uses: 16%
Estimate against measurement, compound 4: 109 percentage points above, outside the stated range (below it).
By their numbers in this assay, from the lowest: compound 4; then compounds 3, 2 and 1 (each within the scatter of the next, the first and the last beyond it).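

In this assay, going by these compounds alone, the step to 3-cyanophenyl in place of 1,2-dihydroxyethyl on a saturated chain carbon bound to an aromatic nitrogen is a number 120 percentage points lower from compound 1 to compound 4 (beyond the scatter), the first single-place reading, and it shows that the response depends strongly on the group at this position. The change is large even though the rest of the structure stays the same, so this position cannot be treated as freely exchangeable. Nothing available bears on the reason for the drop.

The change alters the aromatic ring, the nitrile and the hydroxyl groups in one move, so their separate contributions remain unresolved. From the compounds shown here alone, whether an unsubstituted benzyl, a 3-carboxybenzyl or a simple 2-hydroxyethyl group would keep the response of compound 1 remains open.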